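Working notes: from compound 3 to compound 4

The compounds below may be only part of what the source reports. "The series", "measured", "known", "first", "only" and "open" are said of these compounds alone.

Compound 1 `CCOC(=O)c1cc(/C=C/c2ccccc2)on1`: "not determined" (no result reported)
Compound 2 `CCOC(=O)c1cc(/C=C/c2cccc(Cl)c2)on1`: > 128000 nM
Compound 3 `CCOC(=O)c1cc(/C=C\c2cccc([N+](=O)[O-])c2)on1`: > 128000 nM

Compound 3 gives > 128000 nM in an ADME assay on Vero cells (Chlorocebus sabaeus) for cytotoxicity, with a stated time of 72 h (a lower number here means a stronger inhibitor, a higher number a weaker inhibitor), and that is a limit, not a number. Compound 2 gives > 128000 nM and that too is a limit. Within the data shown here, the only reading so far is the limit of > 128000 nM in this assay, at which 2 of the 3 values shown sit, and compound 1 has no result.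

Against compound 3, compound 4 `CCOC(=O)c1cc(/C=C/c2cccc([N+](=O)[O-])c2)on1` shows one change (the two compounds have the same atoms and bonds and differ only in configuration as drawn: 1 of 1 stereo elements differ; a double bond is drawn Z in compound 3 and E in compound 4). Among the measured compounds shown here, no measured pair shows this change. Compound 2, also drawn E, stays a limit (> 128000 nM) in this assay and so no step beyond the scatter is expected. The expected step is a number no higher from compound 3 to compound 4 (the limit leaves the size open) and it lies within the scatter. For compound 4 the estimated value is 128000 nM with an expected range of 70000 nM to 128000 nM and a report as a limit is likely.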

Compound 4, half-maximal inhibitory concentration: > 128000 nM
Compound 4: only a limit was reported; the forecaster's own chance of this, stated with the estimate: 85%; the middle value sits exactly at the limit.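

Compound 4 gives > 128000 nM, which is a limit, so no step can be read from compound 2 or compound 3 to compound 4. The compounds shown leave open whether double-bond configuration, or nitro in place of chloro, changes the read-out at all.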